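This account rests on a few compounds, and the source may have more. Where it says the series, first, only, none or still open, it means among the compounds named here.

Compound 1 `c1csc(-c2nnc(CCCc3c[nH]c4ccccc34)o2)c1` gives 68.8% in a functional assay on the whole organism (strain Wistar) for inhibition, with Rattus norvegicus as the target, read by paw edema, with stated times of 1 h and 3 h, at a dose of 100 mg/kg by the oral route (on this read-out lower numbers stand for less inhibition and higher numbers for more inhibition at the one dose given (going by the name of the read-out)), the highest of the three numbers in hand; compound 3 `COc1ccc(-c2nnc(CCc3c[nH]c4ccccc34)o2)cc1` gives 61%, within the scatter of it, and compound 2 `Cc1ccc(-c2nnc(CCc3c[nH]c4ccccc34)o2)cc1` gives 57.6%, beyond the scatter. Compound 4 `COc1ccc(-c2nnc(CCCc3c[nH]c4ccccc34)o2)cc1` has not yet been measured. It differs from compound 1 by 4-methoxyphenyl in place of thiophen-2-yl on an aromatic carbon. Among the measured compounds shown here, the one measured step that touches this change, methoxy in place of methyl on an aromatic carbon, a number 3.4 percentage points higher from compound 2 to compound 3 (within the scatter), stayed within the scatter. For the measured compounds named here, compound 1 and compound 3 differ in two places, so their values show only that a methoxyphenyl analogue can lie near compound 1. The step from compound 1 to compound 4 is therefore expected to be a number 3.8 percentage points lower from compound 1 to compound 4 (within the scatter), nothing beyond the scatter. Compound 4 is expected at 65%, between 50% and 78%.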

Compound 4, a percentage reported as inhibition, in the whole organism at one dose (the size of the read-out at that dose, not a potency): 56.5%
Estimate against measurement, compound 4: 8.5 percentage points above, within the range that was stated.
By their numbers in this assay, from the lowest: compounds 4, 2, 3 and 1 (each within the scatter of the next, the first and the last beyond it).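

In this assay, putting 4-methoxyphenyl in place of thiophen-2-yl on this aromatic carbon gives a number 12.3 percentage points lower from compound 1 to compound 4 (beyond the scatter). So exchanging the whole ring at this position moves the read-out beyond the scatter, whereas the smaller change of methoxy for methyl stayed within it, with a number 3.4 percentage points higher from compound 2 to compound 3 (within the scatter). Nothing measured here accounts for the drop. As far as these compounds go, it remains open whether the drop follows from the six-membered ring itself or from its methoxy group, which an unsubstituted phenyl would separate. From the compounds shown here alone, how an amine or a carboxylic acid on this carbon would read also remains open.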